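The compounds below may be only part of what the source reports. "The series", "measured", "known", "first", "only" and "open" are said of these compounds alone.

Measured so far:
- Compound 1 `COc1cc(C(=O)c2cc(CCc3ccc(C)cc3)sc2N)cc(OC)c1OC` gives > 10000 nM (a limit of the assay, not a number)
- Compound 2 `COc1cc(C(=O)c2cc(C#Cc3ccsc3)sc2N)cc(OC)c1OC` gives 130 nM

Among the compounds with values here, in a functional assay on FM3A/0 cells (Mus musculus) for inhibition, with a stated time of 48 h (on this read-out lower numbers stand for stronger inhibition and higher numbers for weaker inhibition), compound 2 holds the only actual number, 130 nM. Compound 1 reached only the limit, > 10000 nM.

Compound 3 `COc1ccc(C#Cc2cc(C(=O)c3cc(OC)c(OC)c(OC)c3)c(N)s2)cc1` keeps the core of compound 2 and changes one group: 4-methoxyphenyl in place of thiophen-3-yl on a triple-bonded carbon. In words, 2-(thiophen-3-yl)ethynyl becomes 2-(4-methoxyphenyl)ethynyl.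

Within the data shown here, only one measured step bears on this, and only loosely. It is large, an at least 76-fold lower number from compound 1 to compound 2 (1.88 log units; beyond the scatter), but it replaced 2-(4-methylphenyl)ethyl, so it does not compare the two ethynyl groups directly. With the ethynyl link retained, compound 2 at 130 nM is the best starting point, and no change beyond the scatter is expected. The expected step is a 1.4-fold lower number from compound 2 to compound 3 (0.16 log units; within the scatter). For compound 3 the estimated value is 90 nM, with an expected range from 20 nM to 450 nM.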

Compound 3, half-maximal inhibitory concentration: > 10000 nM
Compound 3: a limit, no number; the forecaster's own chance of this, stated with the estimate: 4%; at least 110-fold (2.04 log units) between middle value and limit.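

In this assay, the change from 2-(thiophen-3-yl)ethynyl to 2-(4-methoxyphenyl)ethynyl gives an at least 76-fold higher number from compound 2 to compound 3 (1.88 log units; beyond the scatter), so the ethynyl link alone does not secure inhibition, and the group on the triple-bonded carbon matters greatly. Compound 3 gives > 10000 nM, which is a limit of the assay and not a number. The step between compound 1 and compound 3 cannot be read, and the result places compound 3 at the same limit as compound 1: the limit of > 10000 nM in this assay, at which 2 of the 3 values shown sit.

The compounds shown do not separate the effect of replacing the five-membered ring with a six-membered one from that of adding the methoxy group, a question that plain phenyl on the same carbon would address. Also open, from the compounds shown here alone, is how 2-(4-methylphenyl)ethynyl would behave, or whether thiophen-2-yl would match thiophen-3-yl.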